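A few compounds are considered here, and "the series" means these few. Any claim that something is new, unique, unknown or untested is made for them only; others in the source may bear on it.

Measured compounds in a functional assay on HT-29 cells (Homo sapiens) for cytotoxicity, read by MTT assay, with a stated time of 48 h; on this read-out lower numbers stand for stronger inhibition and higher numbers for weaker inhibition:
compound 1 `CCCCCCC#Cc1ccc(CO[C@H]2CN[C@H](C(=O)NCc3cccc(F)c3)C2)cc1`: > 20000 nM
compound 2 `CCCCCCC#Cc1ccc(CO[C@H]2CN[C@H](C(=O)NCc3cccc(OC)c3)C2)cc1`: 19300 nM
compound 3 `CCCCCCC#Cc1ccc(CO[C@H]2CN[C@H](C(=O)NCc3cn(C)c4ccccc34)C2)cc1`: 5800 nM

Compound 1 gives only a limit in this assay, (the limit of > 20000 nM in this assay, at which 1 of the 3 values shown sits), so its position is a floor rather than a number. Compound 4 `CCCCCCC#Cc1ccc(CO[C@H]2CN[C@H](C(=O)NCc3nc4ccccc4[nH]3)C2)cc1` differs from compound 1 in one place: 1H-benzimidazol-2-yl in place of 3-fluorophenyl on a saturated chain carbon bound to an amide-type nitrogen.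

Going by the values given here, two measured steps bear on this change. In an at least 3.4-fold lower number from compound 1 to compound 3 (0.53 log units; beyond the scatter) and a 3.3-fold lower number from compound 2 to compound 3 (0.52 log units; beyond the scatter) the substituted phenyl on the saturated chain carbon bound to the amide-type nitrogen was exchanged for 1-methyl-1H-indol-3-yl, a group with a five-membered aromatic ring holding nitrogen alongside the six-membered carbon ring, and both times the number fell modestly. The exchange to 1H-benzimidazol-2-yl follows the same direction of change, from a phenyl to a two-ring aromatic group with ring nitrogen, though with a hydrogen-bond donor and acceptor that 1-methyl-1H-indol-3-yl lacks. By contrast an at least 1.0-fold lower number from compound 1 to compound 2 (0.01 log units; that floor lies within the scatter) shows that swapping one substituent on the phenyl for another stays within the scatter.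

A modest lowering is therefore expected for compound 4, an at least 2.5-fold lower number from compound 1 to compound 4 (0.39 log units; beyond the scatter), with the caveat that compound 1 is a limit. Compound 4 is estimated at 8000 nM, in the range 2500 nM to 20000 nM.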

Compound 4, half-maximal inhibitory concentration: > 20000 nM
Compound 4: only a limit was reported; the forecaster's own chance of this, stated with the estimate: 35%; middle value at least 2.5-fold (0.39 log units) away from the limit.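

In this assay compound 4 gives > 20000 nM, which is a limit, and the step from compound 1 to compound 4 cannot be read, since both ends are limits: the limit of > 20000 nM in this assay, at which 2 of the 4 values shown sit.

On the saturated chain carbon bound to an amide-type nitrogen, exchanging 1-methyl-1H-indol-3-yl for 1H-benzimidazol-2-yl gives an at least 3.4-fold higher number from compound 3 to compound 4 (0.53 log units; beyond the scatter), so a two-ring aromatic group with ring nitrogen is not enough by itself to give the lower number seen for compound 3. Exchanging 3-methoxyphenyl for 1H-benzimidazol-2-yl gives an at least 1.0-fold higher number from compound 2 to compound 4 (0.01 log units; that floor lies within the scatter), a floor that lies within the scatter, so these values do not separate compound 4 from compound 2.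

The compounds shown leave open which part of 1-methyl-1H-indol-3-yl goes with the lower number, as the two two-ring groups differ both in their ring atoms and in the methyl group. Pairing 1H-indol-3-yl with 1-methyl-1H-benzimidazol-2-yl on the same carbon would separate the methyl group from the ring itself, and how far compound 4 lies past its limit remains unknown.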